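Acetamido on the phenyl ring of compound 2

The compounds below may be only part of what the source reports. "The series", "measured", "known", "first", "only" and "open" are said of these compounds alone.

Compound 1 `CC(C)c1ccc(-c2cc(Cl)cc(C(=O)Nc3nn[nH]n3)n2)cc1`: 90%
Compound 2 `COc1cc(C(=O)Nc2nn[nH]n2)nc(-c2ccccc2)c1`: 100%
Compound 3 `COc1cc(C(=O)Nc2nn[nH]n2)nc(-c2ccc(OC)c(OC)c2)c1`: 51%

Of the compounds shown here, three with a shared core have been measured in a functional assay on the whole organism for inhibition, with Rattus norvegicus as the target, at a dose of 10 mg/kg by the oral route; on this read-out lower numbers stand for a weaker effect and higher numbers for a stronger effect at the one dose given. Compound 1 reaches 90% in this assay, compound 2 gives 100% and compound 3 gives 51%. Compound 2 holds the highest of the three numbers, but the number for compound 1 lies within the usual scatter of it, so the two cannot be ranked against each other; only compound 3 stands clearly lower, beyond the scatter. For the measured compounds named here, no pair among the measured compounds differs in just one place, so no single step can be read from them.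

Compound 4 `COc1cc(C(=O)Nc2nn[nH]n2)nc(-c2ccc(NC(C)=O)cc2)c1` is not yet measured. It differs from compound 2 by acetamido in place of hydrogen on an aromatic carbon, an acetamido in place of hydrogen on an aromatic carbon of the phenyl ring. Going by the values given here, the data give no step of this kind to lean on. Since compound 3, which carries added groups on the same ring, falls to 51%, while compound 2 sits at 100%, a step downward of moderate size is expected, a number 30 percentage points lower from compound 2 to compound 4 (beyond the scatter). Compound 4 is therefore estimated at 70% in this assay, with a range from 35% to 100%.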

Compound 4, a percentage reported as inhibition, in the whole organism at one dose (the size of the read-out at that dose, not a potency): 100%
The estimate for compound 4 lay 30 percentage points below the measured number, and the stated range covers the measured number.
By their numbers in this assay, from the lowest: compound 3; then compounds 1, 2 and 4 (each within the scatter of the next).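

In this assay, for the compounds shown here, the first step that can be read at a single place is no change at the digits printed from compound 2 to compound 4 (within the scatter), so the acetamido on the aromatic carbon para to a large group costs nothing that this read-out can show. The earlier compounds shown here could not show this, since none of them differed in only one place, and the added hydrogen-bond donor and acceptor and the four extra heavy atoms of the acetamido leave the number where it was. No measurement bears on why the effect is kept, and the result gives no reason for it.

Since this assay gives the size of the effect at one dose and not a potency, compound 2 and compound 4 may still differ in ways that this single dose does not reveal. As far as these compounds go, it also remains open whether a free amine or a carboxylic acid on the same carbon, or a longer chain such as butanoylamino in place of the acetamido, would hold the effect at this level.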